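The source may hold more compounds than are shown below. What is called first, only, known or untested is meant among the compounds shown, and "the series" means these compounds.

Working notes on the series.

Cytotoxicity is followed in an ADME assay on HEK293 cells (Homo sapiens) for cytotoxicity, read by CellTiter-Glo and resazurin assay, with a stated time of 72 h; on this read-out higher numbers stand for an effect only at larger amounts of compound and lower numbers for an effect already at smaller amounts. Compound 1, `CC(C)N(Cc1cccc(OCCCCCC(=O)O)c1)C(=O)c1ccc(-c2cccc([N+](=O)[O-])c2)cc1`, gives in this assay a value of > 26000 nM, which is a limit of the assay and not a number. Compound 2, `CCOC(=O)CCCCCOc1cccc(CN(C(=O)c2ccc(-c3cccnc3)cc2)C(C)C)c1`, gives in this assay a value of > 26000 nM, again a limit of the assay rather than a measured number. For the measured compounds named here, both values shown thus sit at the same point, (the limit of > 26000 nM in this assay, at which 2 of the 2 values shown sit), so no step between measured compounds can be drawn, and compound 2 stands at that limit side by side with compound 1, with nothing to separate the two.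

Compound 3, `CCOC(=O)CCCCCOc1cccc(CN(C(=O)c2ccc(-c3cc(OC)ccc3F)cc2)C(C)C)c1`, has not yet been measured in this assay. It differs from compound 2 in one place: 2-fluoro-5-methoxyphenyl in place of pyridin-3-yl on an aromatic carbon. Going by the values given here, the series offers no measured step for a change of this kind.

The step from compound 2 to compound 3 in this assay is expected to be none beyond the scatter, a number no higher from compound 2 to compound 3 (the limit leaves the size open), given that both measured values sit at the limit of > 26000 nM in this assay, at which 2 of the 2 values shown sit. Compound 3 is estimated in this assay at 26000 nM, with a range from 10000 nM to 60000 nM. A further limit rather than a number is the most likely outcome.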

Compound 3, half-maximal effective concentration: > 26000 nM
Compound 3 was reported as a limit; the forecaster's own chance of this, stated with the estimate: 80%; the middle value sits exactly at the limit.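

Compound 3 gives a limit of the assay and not a number, as compound 2 does, so no step from compound 2 to compound 3 can be read in this assay: the limit of > 26000 nM in this assay, at which 3 of the 3 values shown sit.

The compounds shown leave open at what concentration, if any, an effect would appear, and whether 2-fluoro-5-methoxyphenyl in place of pyridin-3-yl changes it.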